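Series notes: chain extension on the benzofuran amide

The source may report more compounds than this note shows. Statements on the series, on what has been measured and on what is new or still open speak of the compounds shown alone.

Compound 2 `CCCCCCCCCCCCNC(=O)[C@@H](NC(=O)c1cc2ccccc2o1)[C@@H](C)O` gives 12900 nM in a functional assay on SiHa cells (Homo sapiens) for cytotoxicity, read by MTT assay, with a stated time of 48 h (a higher number here means a weaker inhibitor, a lower number a stronger inhibitor), the lower of the two numbers obtained so far; compound 1 `CCCCCCCCCCCCNC(=O)[C@@H](NC(=O)c1cccs1)[C@@H](C)O` gives 23900 nM in this assay, and the step of a 1.9-fold lower number from compound 1 to compound 2 (0.27 log units; within the scatter) is within the scatter. Compound 3 `CCCCCCCCCCCCNC(=O)[C@@H](NC(=O)c1cc2ccccc2n1C)[C@@H](C)O` returns only a limit, > 200000 nM in this assay. The steps of an at least 8.3-fold higher number from compound 1 to compound 3 (0.92 log units; beyond the scatter) and an at least 15-fold higher number from compound 2 to compound 3 (1.19 log units; beyond the scatter) are bounded on one side only due to the limit of > 200000 nM in this assay, at which 1 of the 3 values shown sits.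

Compound 4 `CCCCCCCCCCCCCCNC(=O)[C@@H](NC(=O)c1cc2ccccc2o1)[C@@H](C)O` differs from compound 2 in one place: ethyl in place of hydrogen on a saturated chain carbon, ten or more bonds along the chain from an amide-type nitrogen. Among the compounds with values here, every measured step changes the group on the carbonyl carbon and none the chain, so no measured step bears on this change directly; the three measured compounds carry the same chain and give no reading of how its length matters. The group on the carbonyl carbon, which set the steps seen so far, is the same in compound 2 and compound 4. Within the data shown here, the expectation is therefore no step beyond the scatter, a 1.1-fold lower number from compound 2 to compound 4 (0.03 log units; within the scatter), with the uncertainty kept wide on either side as the chain has not yet been varied. Compound 4 is estimated at 12000 nM in this assay, with a range from 4000 nM to 40000 nM.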

Compound 4, half-maximal inhibitory concentration: 14200 nM
Compound 4: middle estimate off by 1.2-fold (0.07 log units), on the low side, within the range that was stated.
By their numbers in this assay, from the lowest: compounds 2, 4 and 1 (each within the scatter of the next). At a limit, above all of these: compound 3.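

In this assay, within the data shown here, the step of a 1.1-fold higher number from compound 2 to compound 4 (0.04 log units; within the scatter) gives the first reading on the chain rather than on the group on the carbonyl carbon: ethyl in place of hydrogen on a saturated chain carbon, ten or more bonds along the chain from an amide-type nitrogen, leaves the number within the scatter. Among these compounds, with 1-benzofuran-2-yl on the carbonyl carbon, this chain position therefore accepts the added ethyl without a measurable shift, whereas the steps beyond the scatter all come from a change of the group on the carbonyl carbon, and this reading covers the one pair only. Nothing shown points to a cause for this result.

From the compounds shown here alone, whether a much shorter chain such as octyl, a longer one such as octadecyl, or a chain ending in an amine or a carboxylic acid would stay in this range remains open. Going by these compounds, compound 3, at > 200000 nM, is a limit and not a number, and whether the longer chain would change the reading with 1-methyl-1H-indol-2-yl or thiophen-2-yl on the carbonyl carbon also remains open.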